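A few compounds are considered here, and "the series" means these few. Any claim that something is new, unique, unknown or untested is made for them only; others in the source may bear on it.

Measured so far:
compound 1 `Cc1ccc2[nH]c(-n3[nH]c(C)c(Cc4ccccc4)c3=O)nc2c1` — 670 nM
compound 2 `Cc1ccc2[nH]c(-n3[nH]c(C)c(C)c3=O)nc2c1` — 2600 nM

In an assay on isolated protein for inhibition of alpha-ketoglutarate-dependent dioxygenase alkB homolog 3 (Homo sapiens), read by polymerase chain reaction, with a stated time of 1 h (a lower number here means a stronger inhibitor, a higher number a weaker inhibitor), compound 1 gives 670 nM, while compound 2 gives 2600 nM, the higher of the two numbers. The only difference between them is the step of a 3.9-fold higher number from compound 1 to compound 2 (0.59 log units; beyond the scatter). Compound 3 `Cc1ccc2[nH]c(-n3[nH]c(C)c(Cc4ccc(Cl)c(Cl)c4)c3=O)nc2c1` is not yet measured; it differs from compound 2 by 3,4-dichlorophenyl in place of hydrogen on a saturated chain carbon bound to an aromatic carbon. This change puts an aromatic ring back onto the same saturated carbon that lost one in the step from compound 1 to compound 2, so that step is the one that bears on it, and it was modest in size. Because a 3.9-fold higher number from compound 1 to compound 2 (0.59 log units; beyond the scatter) went up when the phenyl was removed, the expected direction for compound 3 is a lower number, by a step of about a 5.2-fold lower number from compound 2 to compound 3 (0.72 log units; beyond the scatter). For compound 3 the estimate in this assay is 500 nM, with a range from 150 nM to 1700 nM.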

Compound 3, half-maximal inhibitory concentration: 720 nM
Compound 3: the middle estimate sits 1.4-fold (0.16 log units) below what was measured, and the stated range covers the measured number.
By their numbers in this assay, from the lowest: compounds 1 and 3 (each within the scatter of the next); then compound 2.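

In this assay, the step of a 3.6-fold lower number from compound 2 to compound 3 (0.56 log units; beyond the scatter) shows that the gain from an aromatic ring on this saturated chain carbon is not limited to plain phenyl, since 3,4-dichlorophenyl gives it too. The step of a 1.1-fold higher number from compound 1 to compound 3 (0.03 log units; within the scatter) shows that the two rings cannot be told apart here, so adding the two chlorines brings no measurable gain or loss. Nothing measured here explains why a ring at this place matters.

The compounds shown leave open whether the ring itself is needed, or whether a longer chain such as butyl, with no ring, would do the same. They also leave open how a phenyl carrying a single chlorine, an amine or a carboxylic acid would compare.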